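This account rests on a few compounds, and the source may have more. Where it says the series, first, only, none or still open, it means among the compounds named here.

In a functional assay on OVCAR-3 cells (Homo sapiens) for inhibition, read by MTT assay, with a stated time of 24 h (on this read-out lower numbers stand for stronger inhibition and higher numbers for weaker inhibition), three compounds on a shared core have been measured. Compound 1 `CC1(C)[C@H]2CC[C@]1(C)N(Cc1cn(-c3ccccc3Cl)nn1)C(=O)C2`, with a 2-chlorophenyl, gives 40 nM, and compound 2 `Cc1ccc(-n2cc(CN3C(=O)C[C@@H]4CC[C@@]3(C)C4(C)C)nn2)cc1`, with a 4-methylphenyl, gives 40 nM; the comparison shows no change at the digits printed from compound 1 to compound 2 (within the scatter). Compound 3 `CC1(C)[C@H]2CC[C@]1(C)N(Cc1cn(-c3ccccc3O)nn1)C(=O)C2`, with a 2-hydroxyphenyl, gives 90 nM, the highest number of the three. Compound 4 `Cc1ccccc1-n1cc(CN2C(=O)C[C@@H]3CC[C@@]2(C)C3(C)C)nn1` has not yet been measured. It carries methyl in place of hydroxy on an aromatic carbon, ortho to a large group: methyl in place of hydroxy on an aromatic carbon. Within the data shown here, no measured step makes this exact change, but two bear on it. Hydroxy in place of chloro gave a 2.3-fold higher number from compound 1 to compound 3 (0.35 log units; beyond the scatter), and 2-hydroxyphenyl in place of 4-methylphenyl gave a 2.3-fold higher number from compound 2 to compound 3 (0.35 log units; beyond the scatter). Compound 4 loses the hydroxy and, like compound 1 and compound 2, has none, so a modest move towards a lower number is expected, reversing those steps. The expected change is a 2.3-fold lower number from compound 3 to compound 4 (0.35 log units; beyond the scatter). For compound 4 the estimated value is 40 nM, with an expected range from 18 nM to 90 nM.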

Compound 4, half-maximal inhibitory concentration: 150 nM
Beside the measured number, compound 4's estimate is 3.8-fold (0.57 log units) below it; the whole stated range lies below it.
By their numbers in this assay, from the lowest: compounds 1 and 2 (each within the scatter of the next); then compounds 3 and 4 (each within the scatter of the next).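

In this assay, the place ortho to a large group turns out not to be a simple matter of hydroxy or no hydroxy: methyl in place of hydroxy gives a 1.7-fold higher number from compound 3 to compound 4 (0.22 log units; within the scatter) and so leaves compound 4 level with compound 3 even though it has no hydroxy. The group's identity and location both count on this core, since 2-methylphenyl in place of 4-methylphenyl gives a 3.8-fold higher number from compound 2 to compound 4 (0.57 log units; beyond the scatter) and methyl in place of chloro gives a 3.8-fold higher number from compound 1 to compound 4 (0.57 log units; beyond the scatter) with compound 1 as the partner. Nothing measured here explains why these groups differ. The compounds shown leave open whether the unsubstituted phenyl would stand with compound 1 and compound 2 or with compound 3 and compound 4. They also leave open how a methoxy or an amine would read at this place.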